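The source may report more compounds than this note shows. Statements on the series, on what has been measured and on what is new or still open speak of the compounds shown alone.

The measured compounds:

compound 1, `Cc1nc(S(C)(=O)=O)ccc1Oc1ncnc(OC2CCN(C(=O)OC3CCC3)CC2)c1F`: 13.6 nM
compound 2, `Cc1nc(S(C)(=O)=O)ccc1Oc1ncnc(OC2CCN(C(=O)OC(C)F)CC2)c1F`: 65.5 nM
compound 3, `Cc1nc(S(C)(=O)=O)ccc1Oc1ncnc(OC2CCN(C(=O)SC(C)C)CC2)c1F`: 6.8 nM

All three were tested in a functional assay on isolated protein for inhibition of Glucose-dependent insulinotropic receptor (Homo sapiens), read by HTRF and cAMP accumulation; a higher number here means that more compound is needed for the effect, a lower number that less compound is needed. Compound 3 gives the lowest of the three numbers, but its gap to compound 1, a 2.0-fold lower number from compound 1 to compound 3 (0.30 log units; within the scatter), lies within the scatter, so the two cannot be ranked; only compound 2 stands clearly apart, with a 9.6-fold lower number from compound 2 to compound 3 (0.98 log units; beyond the scatter).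

Compound 4, `Cc1nc(S(C)(=O)=O)ccc1Oc1ncnc(OC2CCN(C(=O)C3CCCC3)CC2)c1F`, has not yet been measured. It differs from compound 3 by cyclopentyl in place of isopropylsulfanyl on a carbonyl carbon.

Both recorded steps that touch the carbonyl carbon bear on this move. The exchange of a ring-bearing group for the isopropylsulfanyl, a 2.0-fold lower number from compound 1 to compound 3 (0.30 log units; within the scatter), was within the scatter; the other, a 9.6-fold lower number from compound 2 to compound 3 (0.98 log units; beyond the scatter), was modest. Neither change reached beyond a modest size, and the entering cyclopentyl is again a ring, as in compound 1. The step from compound 3 to compound 4 is therefore expected to be small, with no clear direction, most likely a 1.6-fold higher number from compound 3 to compound 4 (0.21 log units; within the scatter) and within the scatter. For compound 4 the value in this assay is estimated at 11 nM, with a range from 4 nM to 35 nM.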

Compound 4, half-maximal effective concentration: 72.8 nM
Beside the measured number, compound 4's estimate is 6.6-fold (0.82 log units) below it, outside the stated range (above it).
By their numbers in this assay, from the lowest: compounds 3 and 1 (each within the scatter of the next); then compounds 2 and 4 (each within the scatter of the next).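

In this assay the group on the carbonyl carbon turns out not to be freely exchangeable: cyclopentyl in place of isopropylsulfanyl gives an 11-fold higher number from compound 3 to compound 4 (1.03 log units; beyond the scatter), and cyclopentyl in place of cyclobutyloxy gives a 5.4-fold higher number from compound 1 to compound 4 (0.73 log units; beyond the scatter), so a ring on this carbon does not by itself hold the number low, and both groups that stood at the low end reach the carbonyl carbon through sulfur or oxygen, while cyclopentyl is joined through carbon. Compound 2 goes against any simple reading of that link, since it keeps an oxygen there and still shows a 1.1-fold higher number from compound 2 to compound 4 (0.05 log units; within the scatter), which places two quite different groups at the same level within the scatter. The data shown offer no measurement that would account for these differences.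

As far as these compounds go, each step to compound 4 changes the linking atom and the group beyond it together, so the share of each stays open. Cyclopentyloxy, cyclopentylsulfanyl, or an isopropyl set directly on the carbonyl carbon would separate the two, and an amine at this place would show whether nitrogen behaves like oxygen and sulfur or like carbon.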